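The source may hold more compounds than are shown below. What is called first, only, known or untested is meant among the compounds shown, and "the series" means these compounds.

Working notes on the series. In a functional assay on A549 cells (Homo sapiens) for antiproliferative activity, read by MTT assay (on this read-out lower numbers stand for stronger inhibition and higher numbers for weaker inhibition), compound 1 `Cn1c(=O)c(=O)n(C2CCCC2)c2nc(N/N=C/c3cccc(Cl)c3Cl)ncc21` gives 39100 nM, compound 2 `Cn1c(=O)c(=O)n(C2CCCC2)c2nc(N/N=C/c3cccc([N+](=O)[O-])c3)ncc21` gives 12300 nM, and compound 3 `Cn1c(=O)c(=O)n(C2CCCC2)c2nc(N/N=C/c3ccc(O)c(Br)c3)ncc21` gives 12800 nM. Compound 3 therefore sits alongside compound 2, the pair being a 1.0-fold higher number from compound 2 to compound 3 (0.02 log units; within the scatter), while a 3.1-fold lower number from compound 1 to compound 3 (0.48 log units; beyond the scatter) and a 3.2-fold lower number from compound 1 to compound 2 (0.50 log units; beyond the scatter) set both apart from compound 1. Compound 4 `Cn1c(=O)c(=O)n(C2CCCC2)c2nc(N/N=C/c3cc([N+](=O)[O-])ccc3Cl)ncc21` introduces (2-chloro-5-nitrophenyl in place of 3-bromo-4-hydroxyphenyl on a carbon with a double bond to nitrogen). The entering ring carries the nitro group seen in compound 2 together with a chlorine as in compound 1, and the steps to those two compounds run in opposite directions. For compound 4 the expected step is therefore a 1.6-fold higher number from compound 3 to compound 4 (0.19 log units; within the scatter), a modest move back toward compound 1. Compound 4 is estimated in this assay at 20000 nM, within 7000 nM to 50000 nM.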

Compound 4, half-maximal inhibitory concentration: 8780 nM
Compound 4: middle estimate off by 2.3-fold (0.36 log units), on the high side, and the stated range covers the measured number.
By their numbers in this assay, from the lowest: compounds 4, 2 and 3 (each within the scatter of the next); then compound 1.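

Chloro in place of hydrogen on an aromatic carbon can now be read directly in this assay as a 1.4-fold lower number from compound 2 to compound 4 (0.15 log units; within the scatter) and so does not carry the nitro-bearing ring back toward compound 1. Among the compounds shown here, the 2-chloro-5-nitrophenyl ring is not told apart from 3-bromo-4-hydroxyphenyl, at a 1.5-fold lower number from compound 3 to compound 4 (0.16 log units; within the scatter), yet it stands clear of 2,3-dichlorophenyl, at a 4.5-fold lower number from compound 1 to compound 4 (0.65 log units; beyond the scatter), the widest step so far. No evidence in hand bears on these steps.

Still open, from the compounds shown here alone, is whether a ring carrying an amine or a carboxylic acid in place of the nitro group would sit with compound 2, compound 3 and compound 4 or with compound 1.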